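A Small Change on Compound 3

The compounds below may be only part of what the source reports. "The series", "measured", "known", "first", "only" and "open" are said of these compounds alone.

Three compounds share one core. Compound 1 `Cn1cnc2c(SCc3ccccc3)ncnc21` carries a benzyl group on a sulfur, while compound 2 `CSc1ccc(-c2nc3c(Sc4ccccc4)ncnc3n2C)cc1` and compound 3 `CSc1ccc(-c2nc3c(Sc4ccc(F)cc4)ncnc3n2C)cc1` carry a phenyl on that sulfur and a further aromatic ring on the core. In an assay on isolated protein for inhibition of RAC-alpha serine/threonine-protein kinase (Homo sapiens), tested at 30 uM (on this read-out higher numbers stand for more inhibition at the one concentration tested (going by the name of the read-out) and lower numbers for less inhibition), compound 1 gives 4%, compound 2 gives 5% and compound 3 gives 0%. Going by the values given here, the one step measured between neighbours, a number 5 percentage points lower from compound 2 to compound 3 (within the scatter), is too small to count. Compound 3 therefore sits among the others: its gaps to compound 1 and to compound 2 both lie within the scatter, so no order among the three can be read from these numbers.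

Compound 4 `Cn1c(-c2ccc([S+](C)[O-])cc2)nc2c(Sc3ccc(F)cc3)ncnc21` differs from compound 3 in one place: a group of 3 heavy atoms (1 carbon, 1 oxygen, 1 sulfur; no ring) in place of a group of 2 heavy atoms (1 carbon, 1 sulfur; no ring), on an aromatic carbon. Among the compounds with values here, no measured step touches this part of the molecule; the only step available, the fluoro for hydrogen change from compound 2 to compound 3, was within the scatter and sits elsewhere. With every measured number close to zero and no evidence of movement anywhere in the set, the expectation for compound 4 is a step of a number 3 percentage points higher from compound 3 to compound 4 (within the scatter) that stays within the scatter. Compound 4 is therefore estimated at 3%, with a range from -8% to 14%.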

Compound 4, a percentage reported as inhibition, at one concentration (the size of the read-out at that concentration, not a potency): 10%
Estimate against measurement, compound 4: 7 percentage points below; the range from low to high includes it.
By their numbers in this assay, from the lowest: compounds 3, 1, 2 and 4 (each within the scatter of the next).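

Going by these compounds alone, this is the first measured change at this place on the ring, the aromatic carbon para to a large group, where the methylsulfanyl group gives way to a group that also holds an oxygen. In this assay, that exchange gives a number 10 percentage points higher from compound 3 to compound 4 (within the scatter), so it cannot be told apart from ordinary repeat-to-repeat variation, and the earlier fluoro step, made elsewhere on the molecule, could say nothing about this place. No independent information here bears on why the number came out as it did.

The compounds shown leave open whether any group at this place can move the read-out clearly beyond the scatter, and what an amine, a carboxylic acid or a longer chain would do there remains unknown. They also leave open how this exchange would behave on a molecule with a clearly larger starting number, since a single-concentration read-out near zero, as here, leaves little room to see a change and gives no measure of potency.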